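A few compounds are considered here, and "the series" means these few. Any claim that something is new, unique, unknown or untested is made for them only; others in the source may bear on it.

In a functional assay on PC-3 cells (Homo sapiens) for antiproliferative activity, read by MTT assay, with a stated time of 72 h (a lower number here means a stronger inhibitor, a higher number a weaker inhibitor), compound 1 (`CCN(CC)CCNC(=O)c1ccc(C(CC)(CC)c2ccc(OCC(O)C(C)(C)C)c(C)c2)n1CC`) gives 2800 nM and compound 2 (`CCn1c(C(=O)NCCC(=O)O)ccc1C(CC)(CC)c1ccc(C#CC(O)(CC)CC)c(C)c1`) gives 5130 nM while compound 3 (`CCN(CC)CCNC(=O)c1cc(C(CC)(CC)c2ccc(C#CC(O)(CC)CC)c(C)c2)cn1CC`) gives 5350 nM as its reading. Compound 3 stands within the scatter of both other compounds, so the three values do not separate. The next structure is compound 4 (`CCn1cc(C(CC)(CC)c2ccc(C#CC(O)(CC)CC)c(C)c2)cc1C(=O)OCCO`), still unmeasured. The change from compound 3 (2-hydroxyethoxy in place of (2-(diethylamino)ethyl)amino on a carbonyl carbon) puts 2-hydroxyethoxy in place of (2-(diethylamino)ethyl)amino on a carbonyl carbon, which turns (2-(diethylamino)ethyl)carbamoyl into (2-hydroxyethoxy)carbonyl. Among the compounds with values here, no measured pair differs in one place only, so no step in this assay can be read directly for this change. Compound 2 at 5130 nM and compound 3 at 5350 nM differ in more than one place yet remain within the scatter of each other, so no step beyond the scatter is expected, and no firm direction. The expected step runs a 1.2-fold lower number from compound 3 to compound 4 (0.08 log units; within the scatter) and stays inside the scatter. Compound 4 is expected at 4500 nM with an estimated range of 2000 nM to 10000 nM.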

Compound 4, half-maximal inhibitory concentration: 11400 nM
The estimate for compound 4 lay 2.5-fold (0.40 log units) below the measured number; measured number above the stated range.
By their numbers in this assay, from the lowest: compounds 1, 2 and 3 (each within the scatter of the next); then compound 4.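

In this assay, within the data shown here, 2-hydroxyethoxy in place of (2-(diethylamino)ethyl)amino on a carbonyl carbon gives a 2.1-fold higher number from compound 3 to compound 4 (0.33 log units; beyond the scatter), the only step that can be read across a single place. In this one pair, the group on the carbonyl carbon does move the read-out, and (2-(diethylamino)ethyl)carbamoyl gives the lower number of the two. No measured property bears on this step, so it remains an observation without an assigned cause.

The change swaps the atom bonded to the carbonyl carbon, the end group and the chain size together, so this pair cannot show which of these carries the step. A (2-hydroxyethyl)amino group or a 2-(diethylamino)ethoxy group on the same carbonyl carbon would separate these parts, and a carboxylic acid there would test the bare carbonyl end.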